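A few compounds are considered here, and "the series" means these few. Any claim that something is new, unique, unknown or untested is made for them only; others in the source may bear on it.

Compound 3 `COc1cc(OC)c(OC)cc1/C=C/COC(=O)/C=C/c1ccc(F)cc1` gives 100% in a functional assay on the whole organism (strain Kunming) with Mus musculus as the target, with a stated time of 0.5 h, at a dose of 100 mg/kg by the intraperitoneal route; on this read-out lower numbers stand for a stronger effect and higher numbers for a weaker effect at the one dose given. Compound 1 `COc1ccccc1/C=C/C(=O)OC/C=C/c1cc(OC)c(OC)cc1OC` gives 100% and compound 2 `COc1cc(OC)c(OC)cc1/C=C/COC(=O)/C=C/c1c(OC)ccc(OC)c1OC` gives 100% in this assay, so compound 3 stands level with both at the digits shown. Among the compounds with values here, the one single-point step among the measured compounds, no change at the digits printed from compound 1 to compound 3 (within the scatter), shows that exchanging the substituted phenyl on a double-bonded chain carbon bound to a double-bonded chain carbon left the read-out unmoved.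

Compound 4 `COc1cc(OC)c(OC)cc1/C=C/COC(=O)/C=C/c1ccccc1C(F)(F)F` has not yet been measured in this assay. It differs from compound 3 as follows: 2-(trifluoromethyl)phenyl in place of 4-fluorophenyl on a double-bonded chain carbon bound to a double-bonded chain carbon. This change is covered by one measured step because no change at the digits printed from compound 1 to compound 3 (within the scatter) also replaced the substituted phenyl at the same place and stayed flat within the scatter. Within the data shown here, no measured step shows any such exchange moving this read-out. Compound 4 is therefore expected to give 100%, with a range from 85% to 100%. The expected step of no change at the digits printed from compound 3 to compound 4 (within the scatter) is estimated to be none beyond the scatter.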

Compound 4, a percentage reported as activity, at one dose (the size of the read-out at that dose, not a potency): 100%
Estimate against measurement, compound 4: no gap at the digits printed; the range from low to high includes it.
By their numbers in this assay, from the lowest: compounds 1, 2, 3 and 4 (each within the scatter of the next).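

Putting 2-(trifluoromethyl)phenyl in place of 4-fluorophenyl on a double-bonded chain carbon bound to a double-bonded chain carbon brought no change at the digits printed from compound 3 to compound 4 (within the scatter) in this assay and so extends the flat result to a larger group with more heavy atoms at this place. Trifluoromethyl in place of methoxy on an aromatic carbon brought no change at the digits printed from compound 1 to compound 4 (within the scatter) as well, a direct exchange of one substituent for the other that the earlier compounds did not offer. No measurement given here bears on why the read-out stays flat.

With all four compounds level, nothing shown yet identifies a change that moves this read-out. From the compounds shown here alone, whether an amine or a carboxylic acid on this phenyl would shift it remains open, as does the effect of an amide in place of the ester.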